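Hydroxy for Methoxy on a Pyrazole Urea Series

This account rests on a few compounds, and the source may have more. Where it says the series, first, only, none or still open, it means among the compounds named here.

Compounds measured so far:
Compound 1 `O=C(Nc1cccc(-n2cc(-c3ccncc3)c(-c3ccc(Cl)c(O)c3)n2)c1)Nc1cccc(C(F)(F)F)c1`, 3650 nM in a functional assay on SNB-75 cells (Homo sapiens) for inhibition, read by sulforhodamine B assay, with a stated time of 48 h; on this read-out higher numbers stand for weaker inhibition of growth and lower numbers for stronger inhibition of growth.
Compound 2 `COc1cc(-c2nn(-c3cccc(NC(=O)Nc4ccc(Cl)c(C(F)(F)F)c4)c3)cc2-c2ccncc2)ccc1Cl`, 1280 nM in this assay.

Compound 2 stands at the lower of the two numbers in this assay, and its gap to compound 1 is beyond the usual scatter, so compound 2 is the stronger growth inhibitor of the pair. Compound 3 `O=C(Nc1cccc(-n2cc(-c3ccncc3)c(-c3ccc(Cl)c(O)c3)n2)c1)Nc1ccc(Cl)c(C(F)(F)F)c1` has not yet been measured in this assay. It differs from compound 2 in one place: hydrogen in place of methyl on an oxygen on an aromatic ring. Among the compounds with values here, compound 1 already carries the hydroxy on that ring while bearing a different aryl on the urea, so no pair of measured compounds isolates the methoxy-to-hydroxy exchange on its own, and the size of this step in this assay is not known from the data. The account expects a modest weakening of growth inhibition for compound 3, so that the step of a 1.6-fold higher number from compound 2 to compound 3 (0.19 log units; within the scatter) is estimated to be small and may well fall within the scatter. On that basis compound 3 is estimated at 2000 nM in this assay, with a likely range from 800 nM to 5000 nM.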

Compound 3, concentration for 50% growth inhibition: 678 nM
For compound 3 the middle estimate is 2.9-fold (0.47 log units) above the measured one; measured number below the stated range.
By their numbers in this assay, from the lowest: compounds 3 and 2 (each within the scatter of the next); then compound 1.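

In this assay, the exchange of methoxy for hydroxy can now be read on its own, on the 4-chloro-3-methoxyphenyl to 4-chloro-3-hydroxyphenyl change, and it gives a 1.9-fold lower number from compound 2 to compound 3 (0.28 log units; within the scatter) with the rest of the molecule held constant, so this pair does not separate the two groups in this read-out. Within the data shown here, the same compound also provides the first single change on the aryl of the urea, where chloro in place of hydrogen on an aromatic carbon gives a 5.4-fold lower number from compound 1 to compound 3 (0.73 log units; beyond the scatter) with the hydroxy kept in place, a step that, unlike the exchange on the oxygen, lies beyond the usual scatter. Nothing measured among these compounds points to a cause for either step.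

Whether methoxy and hydroxy also stay within the scatter of each other on the urea aryl without the chloro remains open, as the methoxy partner of compound 1 is not among the compounds shown. It is equally unknown how an ethoxy group or an amine would compare on that aromatic ring, or how a fluoro or a methyl group would compare with the chloro on the urea aryl.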